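Cytotoxicity of pyrrolidinone amides: a larger sulfonamide substituent

The source may report more compounds than this note shows. Statements on the series, on what has been measured and on what is new or still open speak of the compounds shown alone.

Measured compounds:
- compound 1, `COc1ccc([C@H]2CC(=O)N(c3ccc(N)cc3)C2)cc1OC1CCCC1`: > 10000 nM in a functional assay on HEK293 cells (Homo sapiens) for cytotoxicity; on this read-out higher numbers stand for lower toxicity in this test and lower numbers for higher toxicity in this test (a limit)
- compound 2, `COc1ccc([C@H]2CC(=O)N(c3ccccc3C#N)C2)cc1OC1CCCC1`: > 10000 nM (a limit)
- compound 3, `COc1ccc([C@H]2CC(=O)N(c3cccc(S(C)(=O)=O)c3)C2)cc1OC1CCCC1`: > 10000 nM (a limit)

In this assay compound 3 stands at a limit: its value of > 10000 nM is a boundary of the test, not a measured number. The same holds for the two other compounds, and so the limit of > 10000 nM in this assay, at which 3 of the 3 values shown sit, is the whole picture so far. The three steps between them, a step that the two limits leave unreadable from compound 1 to compound 2, a step that the two limits leave unreadable from compound 1 to compound 3 and a step that the two limits leave unreadable from compound 2 to compound 3, therefore have no readable size.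

Compound 4, `COc1ccc([C@H]2CC(=O)N(c3cccc(NS(=O)(=O)c4cccc(Cl)c4)c3)C2)cc1OC1CCCC1`, differs from compound 3 in one place: ((3-chlorophenyl)sulfonyl)amino in place of methylsulfonyl on an aromatic carbon. Within the data shown here, no measured step involves a change of this kind, so none bears on it directly, and nothing in the measured steps gives a size or a direction for this one.

Compound 4 is therefore expected to sit at or near the same limit, estimated at 12000 nM with a range from 3000 nM to 40000 nM, which means an expected step that the limit leaves unreadable from compound 3 to compound 4.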

Compound 4, half-maximal cytotoxic concentration: > 10000 nM
Compound 4 ended at the assay's limit (the forecaster's own chance of this, stated with the estimate: 70%); the middle value is on the limit's open side.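

In this assay compound 4 gives > 10000 nM, which is a limit and not a number. Among these compounds, compound 3 also sits at a limit, so no step between compound 3 and compound 4 can be read. The compounds shown leave open at what concentration any of them would harm these cells, as the picture remains this: the limit of > 10000 nM in this assay, at which 4 of the 4 values shown sit.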